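This account rests on a few compounds, and the source may have more. Where it says the series, first, only, none or still open, it means among the compounds named here.

Three hydroxamic acids sharing one core have been measured in a functional assay on SK-OV-3 cells (Homo sapiens) for cytotoxicity; on this read-out higher numbers stand for weaker inhibition and lower numbers for stronger inhibition. Compound 1 `O=C(CCCCCCc1nc2ccc(F)cc2[nH]1)NO` carries a fluoro group on the core and gives 1900 nM. Compound 2 `O=C(CCCCCCc1nc2ccc(-c3ccccc3F)cc2[nH]1)NO` carries a 2-fluorophenyl group in the same place and gives 7400 nM. Compound 3 `CN(C)c1ccc(-c2ccc3nc(CCCCCCC(=O)NO)[nH]c3c2)cc1` carries a 4-(dimethylamino)phenyl group there and gives 6600 nM, the second highest of the three numbers; compound 2 lies within the scatter of compound 3, while compound 1 sits well below.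

The single-step comparisons show that both aryl groups raise the number relative to the small fluoro group: a 3.9-fold higher number from compound 1 to compound 2 (0.59 log units; beyond the scatter) and a 3.5-fold higher number from compound 1 to compound 3 (0.54 log units; beyond the scatter), whereas a 1.1-fold lower number from compound 2 to compound 3 (0.05 log units; within the scatter).

Compound 4 `CN(C)c1ccc2nc(CCCCCCC(=O)NO)[nH]c2c1` differs from compound 3 in one place: dimethylamino in place of 4-(dimethylamino)phenyl on an aromatic carbon. This removes the aromatic ring that, in compound 3 and compound 2, accompanied a higher number than in compound 1. For the measured compounds named here, no measured pair shows a dimethylamino group sitting directly on the core, so the only guide is that the compound without an added aryl ring, compound 1, gave the lowest number.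

Compound 4 is therefore expected to show a lower number than compound 3, with an estimated step of a 2.6-fold lower number from compound 3 to compound 4 (0.42 log units; beyond the scatter). The estimate for compound 4 is 2500 nM, with a range from 1000 nM to 6500 nM.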

Compound 4, half-maximal inhibitory concentration: 1200 nM
Beside the measured number, compound 4's estimate is 2.1-fold (0.32 log units) above it, within the range that was stated.
By their numbers in this assay, from the lowest: compounds 4 and 1 (each within the scatter of the next); then compounds 3 and 2 (each within the scatter of the next).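

In this assay, removing the phenyl ring and leaving the dimethylamino group directly on the core gives a 5.5-fold lower number from compound 3 to compound 4 (0.74 log units; beyond the scatter), so the higher number of compound 3 goes with the added ring and not with the dimethylamino group alone. The same pattern appears against the other aryl compound, with a 6.2-fold lower number from compound 2 to compound 4 (0.79 log units; beyond the scatter), whereas the change from fluoro to dimethylamino gives a 1.6-fold lower number from compound 1 to compound 4 (0.20 log units; within the scatter), so the two compounds with no added ring at this position cannot be told apart, and both aryl compounds stand clearly higher. The data offer no measured explanation of why an added aryl ring goes with a higher number in these cells.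

From the compounds shown here alone, it remains open whether any ring at this position raises the number, as a plain phenyl or a saturated piperidine ring would help to show, or whether the two aryl groups here are special cases. Going by these compounds, it is also open whether other small groups, such as a primary amine or a carboxylic acid, would stay level with fluoro and dimethylamino, and whether the pattern would hold with a longer chain leading to the hydroxamic acid.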